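Methoxy to ethoxy: working notes on compound 3

This account rests on a few compounds, and the source may have more. Where it says the series, first, only, none or still open, it means among the compounds named here.

For the measured compounds named here, in a functional assay on MCF7 cells (Homo sapiens) for cytotoxicity, read by XTT assay, with a stated time of 24 h (a lower number here means a stronger inhibitor, a higher number a weaker inhibitor), compound 1 (`COc1c(C)cc(Cl)c2c1C(=O)C=CC2=O`) gives 16200 nM as the lower of the two numbers so far, which makes it the stronger inhibitor of the measured pair. Compound 2 (`CC(=O)Oc1cc(C)c(Cl)c2c1C(=O)C=CC2=O`) gives 37900 nM as the higher number, and the gap between the two lies beyond the usual scatter. These two compounds differ in more than one place, so the gap cannot be tied to any single change.

Compound 3 (`CCOc1c(C)cc(Cl)c2c1C(=O)C=CC2=O`) differs from compound 1 by one change (methyl in place of hydrogen on a saturated chain carbon bound to an oxygen on an aromatic ring) that places methyl in place of hydrogen on a saturated chain carbon bound to an oxygen on an aromatic ring, reading as methoxy to ethoxy. Going by the values given here, no measured pair shows this change, so the expectation rests only on its small size and on the value of compound 1. In this assay the expected move is a 1.1-fold higher number from compound 1 to compound 3 (0.05 log units; within the scatter) and no change beyond the scatter is expected. The estimate for compound 3 is 18000 nM with an expected range of 8000 nM to 40000 nM for this measurement.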

Compound 3, half-maximal inhibitory concentration: 32200 nM
For compound 3 the middle estimate is 1.8-fold (0.25 log units) below the measured one; the range from low to high includes it.
By their numbers in this assay, from the lowest: compounds 1, 3 and 2 (each within the scatter of the next, the first and the last beyond it).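

For the compounds shown here, the pair of compound 1 and compound 3 is the first that differs in one place, so it gives the first direct reading of a change on the saturated chain carbon bound to an oxygen on an aromatic ring: in this assay, methoxy to ethoxy gives a 2.0-fold higher number from compound 1 to compound 3 (0.30 log units; within the scatter) as its step. On this single pair, methyl in place of hydrogen at this place cannot be told apart from repeat measurement, while compound 2 differs from both in more than one place and adds nothing to this reading. No available measurement speaks to a cause for the numbers at this place.

The compounds shown leave open whether a longer chain such as propyl on the same oxygen, or a chain ending in an amine or a carboxylic acid, would also stay within the scatter of compound 1. They also leave open whether the step from methoxy to ethoxy would read the same on another core or in a different cell line, since one pair in one assay sets no trend.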